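Ring size at the chain end: five to six members

The source may report more compounds than this note shows. Statements on the series, on what has been measured and on what is new or still open speak of the compounds shown alone.

Measured compounds:
- compound 1, `Cc1cc(-n2cc(C(=O)Nc3cc(F)cc(F)c3)c(=O)c3ccc(N(C)C)nc32)ccc1OCCCCCCC[N+]1(C)CCCC1`: 26.1%
- compound 2, `Cc1ccc(-n2cc(C(=O)Nc3cc(F)cc(F)c3)c(=O)c3ccc(N(C)C)nc32)cc1OCCCCCCC[N+]1(C)CCCC1`: 12.7%
- compound 3, `Cc1cc(-n2cc(C(=O)Nc3cc(F)cc(F)c3)c(=O)c3ccc(N(C)C)nc32)ccc1OCCCCCCC[N+]1(C)CCCCC1`: 33%

All three were tested in an assay on LX2 cells for inhibition of COL1A1 promoter (Homo sapiens), read by a luciferase reporter, with a stated time of 24 h, tested at 20 uM; on this read-out lower numbers stand for a weaker effect and higher numbers for a stronger effect at the one concentration tested. Compound 1 and compound 2 share the same atoms joined differently; how their two cores differ is not broken down here. Compound 2 gives the lowest of the three numbers, and its gaps to compound 1 and to compound 3 both lie beyond the scatter.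

From compound 1 to compound 3 the change is a group of 7 heavy atoms (6 carbon, 1 nitrogen; one six-membered non-aromatic ring with 1 hetero atom) in place of a group of 6 heavy atoms (5 carbon, 1 nitrogen; one five-membered non-aromatic ring with 1 hetero atom), on a saturated chain carbon, seven bonds along the chain from an oxygen on an aromatic ring, and the step that came with it was a number 6.9 percentage points higher from compound 1 to compound 3 (within the scatter). The new compound 4, `Cc1ccc(-n2cc(C(=O)Nc3cc(F)cc(F)c3)c(=O)c3ccc(N(C)C)nc32)cc1OCCCCCCC[N+]1(C)CCCCC1`, is made from compound 2 by the same change, (a group of 7 heavy atoms (6 carbon, 1 nitrogen; one six-membered non-aromatic ring with 1 hetero atom) in place of a group of 6 heavy atoms (5 carbon, 1 nitrogen; one five-membered non-aromatic ring with 1 hetero atom), on a saturated chain carbon, seven bonds along the chain from an oxygen on an aromatic ring), at the same place. The expectation for compound 4 rests on that single earlier step: it lay within the scatter, so a step of similar size is expected from compound 2, namely a number 6.3 percentage points higher from compound 2 to compound 4 (within the scatter). With compound 2 at 12.7% as the starting point, compound 4 is therefore estimated to give 19% in this assay, with a range from 8% to 30%.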

Compound 4, a percentage reported as inhibition, at one concentration (the size of the read-out at that concentration, not a potency): 23.4%
The estimate for compound 4 lay 4.4 percentage points below the measured number; low and high end bracket the measured number.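

In this assay, putting the six-membered ring in place of the five-membered ring at the chain end comes with a number 10.7 percentage points higher from compound 2 to compound 4 (beyond the scatter). Set beside the same change on the other core, the two steps agree: the same change on two cores in this assay, a number 6.9 percentage points higher (within the scatter) from compound 1 to compound 3 and a number 10.7 percentage points higher (beyond the scatter) from compound 2 to compound 4, 3.8 percentage points apart, within the scatter of two such steps
So in these two matched pairs the change carries from one core to the other with a similar size, but the two steps alone cannot show that it would carry to any further core, and as readings at a single concentration they say nothing about potency.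

The compounds shown leave open whether a morpholine ring or an open-chain trimethylammonium group at the chain end would fit the same picture, and whether a shorter or longer chain would alter the size of the step. They also leave open how the change would behave on a core other than these two.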